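The source may hold more compounds than are shown below. What is called first, only, known or untested is meant among the compounds shown, and "the series" means these compounds.

Compound 1 `O=c1nc2ccc(Cl)cn2cc1Cc1ccc(F)cc1C(F)(F)F` was tested in a functional assay on A549 cells (Homo sapiens) for cytotoxicity, read by MTT assay, with a stated time of 24 h; on this read-out higher numbers stand for weaker inhibition and lower numbers for stronger inhibition. Compound 1 gives > 1000000 nM, which is a limit of the assay rather than a measured number. Compound 2 `O=c1nc2ccccn2cc1Cc1ccc(F)cc1C(F)(F)F`, carrying hydrogen in place of chloro on an aromatic carbon, gives > 1000000 nM in this assay; this too is a limit. The step that the two limits leave unreadable from compound 1 to compound 2 therefore cannot be read, since (the limit of > 1000000 nM in this assay, at which 2 of the 2 values shown sit). Compound 1 thus stands only at a limit, with no number of its own to compare against.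

Compound 3 `O=c1nc2ccc(Cl)cn2cc1Cc1ccc(F)cc1` differs from compound 1 as follows: hydrogen in place of trifluoromethyl on an aromatic carbon. Among the compounds with values here, no measured step touches the trifluoromethyl group, and the one step that has been measured, from chloro to hydrogen, gave no readable size. There is therefore nothing in the measurements that points to a step in this assay in either direction beyond the scatter, and the most plausible outcome is that compound 3 again reaches the limit. Compound 3 is estimated at 1000000 nM, expected to lie between 300000 nM and 3000000 nM. The step this implies, a number no higher from compound 1 to compound 3 (the limit leaves the size open), is expected to be none beyond the scatter.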

Compound 3, half-maximal inhibitory concentration: 98300 nM
Estimate against measurement, compound 3: 10-fold (1.01 log units) above; the measured number lies below the stated range.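

Within the data shown here, putting hydrogen in place of the trifluoromethyl group is the first change here that gives a readable shift: in this assay, it gives an at least 10-fold lower number from compound 1 to compound 3 (1.00 log units; beyond the scatter). The earlier compounds shown here could not show that this position, on the six-membered aromatic ring of carbon only, ortho to a large group and meta to a fluoro group, can alter the read-out, and compound 3 is the only one of the three with a measured number, 98300 nM. The step gives only a minimum size, and its true size remains unknown because compound 1 stands at a limit and has no number of its own: the limit of > 1000000 nM in this assay, at which 2 of the 3 values shown sit.

The compounds shown do not tell whether a methyl group, a methoxy group, an amine or a carboxylic acid at this position would give a number closer to that of compound 3 or would return to the limit. They also leave open whether the chloro group affects the read-out when hydrogen occupies this position, since no compound shown pairs that hydrogen with hydrogen in place of the chloro group.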